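A few compounds are considered here, and "the series" means these few. Any claim that something is new, unique, unknown or untested is made for them only; others in the source may bear on it.

Compound 1 `CN(C)C(=S)N/N=C/c1ccc2cccnc2n1` and compound 3 `CN(C)C(=S)N/N=C/c1cnc2ccccc2n1` share the same atoms joined differently; the difference between the two cores is not broken down here. In a functional assay on HT-29 cells (Homo sapiens) for antiproliferative activity, read by sulforhodamine B assay, with a stated time of 72 h (on this read-out lower numbers stand for stronger inhibition and higher numbers for weaker inhibition), compound 1 gives 410 nM, and compound 3 gives 450 nM, two values within the usual scatter of each other. Compound 2 `NC(=S)N/N=C/c1ccc2cccnc2n1` differs from compound 1 by an (amino in place of dimethylamino on a thiocarbonyl carbon), and in this assay compound 2 gives 12800 nM; that single change made a 31-fold higher number from compound 1 to compound 2 (1.49 log units; beyond the scatter). Compound 4 `NC(=S)N/N=C/c1cnc2ccccc2n1` differs from compound 3 by the same change, an (amino in place of dimethylamino on a thiocarbonyl carbon). This expectation rests on one measured instance of the change, a 31-fold higher number from compound 1 to compound 2 (1.49 log units; beyond the scatter), and on compound 1 and compound 3 starting from closely matched values. A step of similar size is expected, a 27-fold higher number from compound 3 to compound 4 (1.43 log units; beyond the scatter). Compound 4 is estimated to give 12000 nM in this assay, with a likely range from 3500 nM to 40000 nM.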

Compound 4, half-maximal inhibitory concentration: > 100000 nM
Compound 4 was reported as a limit; the forecaster's own chance of this, stated with the estimate: 5%; at least 8.3-fold (0.92 log units) between middle value and limit.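

In this assay compound 4 gives > 100000 nM, which is a limit of the assay and not a number. Amino in place of dimethylamino gives an at least 220-fold higher number from compound 3 to compound 4 (2.34 log units; beyond the scatter), so the direction of the earlier step carries over to this second core, but its size does not: the same change on two cores in this assay, a 31-fold higher number (1.49 log units; beyond the scatter) from compound 1 to compound 2 and an at least 220-fold higher number (2.34 log units; beyond the scatter) from compound 3 to compound 4, at least 7.1-fold (0.85 log units) apart, beyond the scatter of two such steps. The true size of the step on this core stays unknown, and the two pairs do not show why the cores part, since compound 4 sits at a limit: the limit of > 100000 nM in this assay, at which 1 of the 4 values shown sits.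

The compounds shown leave open how methylamino, or a longer chain such as diethylamino, would fare on the thiocarbonyl carbon of either core.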